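Efficacy at the D(4) receptor: swapping the piperazine aryl group

The compounds below may be only part of what the source reports. "The series", "measured", "known", "first", "only" and "open" are said of these compounds alone.

Measured compounds:
- compound 1, `Cc1ccccc1/C(CCN1CCN(c2ccccn2)CC1)=N/O`: 82%
- compound 2, `CCO/N=C(\CCN1CCN(c2ccccc2)CC1)c1ccccc1`: 80%

Both compounds were read in a functional assay on HEK293 cells with D(4) dopamine receptor (Homo sapiens) as the target, read by FLIPR; a higher number here means a larger maximal response, a lower number a smaller maximal response. Compound 2 has the lower of the two numbers, but the nearest other value, that of compound 1, lies only slightly higher and within the scatter of this measurement, so the two compounds are best regarded as giving the same maximal response.

For the measured compounds named here, the next compound, compound 3, `CCO/N=C(\CCN1CCN(c2ncccc2C)CC1)c1ccccc1`, has not yet been read in this assay. It differs from compound 2 in one place: 3-methylpyridin-2-yl in place of phenyl on an amine nitrogen in a ring.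

Going by the values given here, no measured pair here shows what this kind of exchange does. What the two measured compounds do show is that a change of the group on the amine nitrogen in the ring, from compound 1 to compound 2, did not move the maximal response beyond the scatter. On that basis the step from compound 2 to compound 3 is expected to be small, no change at the digits printed from compound 2 to compound 3 (within the scatter), with no clear direction. For compound 3 the estimated value in this assay is 80%, expected to fall between 65% and 92%.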

Compound 3, largest response reached (reported as efficacy), in percent of the reference or control that the assay uses: 49%
For compound 3 the middle estimate is 31 percentage points above the measured one; measured number outside the range, below it.
By their numbers in this assay, from the lowest: compound 3; then compounds 2 and 1 (each within the scatter of the next).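

In this assay, the group on the amine nitrogen in the ring turns out to matter for the maximal response: the change gives a number 31 percentage points lower from compound 2 to compound 3 (beyond the scatter), so this position is sensitive to at least this exchange. The exchange alters two things at once, since 3-methylpyridin-2-yl brings both a nitrogen in the aromatic ring, with the hydrogen-bond acceptor counted for it, and a methyl group that phenyl lacks, so the step cannot be assigned to either feature alone. Nothing among the data available here explains why the response falls.

The compounds shown leave open whether the ring nitrogen, the methyl group or the two together account for the lower response; a methylphenyl group on the same nitrogen, in the core of compound 2, would help to separate these. They also leave open how other groups at this position, such as a chlorophenyl or a naphthyl group, would behave in this assay.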